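Stripping the methoxy group from compound 3

A few compounds are considered here, and "the series" means these few. Any claim that something is new, unique, unknown or untested is made for them only; others in the source may bear on it.

Compound 1 `CSc1ccc(CNc2nc(SC)nc3ncccc23)cc1` gives 3770 nM in an ADME assay on BEAS-2B cells (Homo sapiens) for cytotoxicity, read by MTT assay, with a stated time of 72 h; on this read-out lower numbers stand for stronger inhibition of growth and higher numbers for weaker inhibition of growth.
Compound 2 `[SeH]c1nc(NCc2ccccc2)c2cccnc2n1` gives > 100000 nM in this assay.
Compound 3 `COc1ccc(CNc2nc(SC)nc3ncccc23)cc1` gives > 100000 nM in this assay.

Compound 3 stands at the top of the scale: its value of > 100000 nM is a limit of the assay, not a number. The same holds for compound 2, whose > 100000 nM is also a limit. Both sit at the limit of > 100000 nM in this assay, at which 2 of the 3 values shown sit. Among the measured compounds shown here, only compound 1 returns a number, and the single measured step, methoxy in place of methylsulfanyl on the aromatic carbon, gives an at least 26-fold higher number from compound 1 to compound 3 (1.42 log units; beyond the scatter).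

Compound 4 `CSc1nc(NCc2ccccc2)c2cccnc2n1` differs from compound 3 by hydrogen in place of methoxy on an aromatic carbon. For the measured compounds named here, no measured step removes a group from that ring, so the evidence bearing on it is only indirect: compound 1 shows that the same position can carry a group and still give a number, while compound 3 shows that a different group there reaches the limit. The step from compound 3 to compound 4 is therefore uncertain, and compound 4 is expected to land somewhere between those two outcomes. For compound 4 the expected step is an at least 3.3-fold lower number from compound 3 to compound 4 (0.52 log units; beyond the scatter). Compound 4 is thus estimated at 30000 nM, within a range from 5000 nM to 100000 nM.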

Compound 4, concentration for total growth inhibition: 61700 nM
For compound 4 the middle estimate is 2.1-fold (0.31 log units) below the measured one, and the stated range covers the measured number.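

Hydrogen on this aromatic carbon gives the position its first measured reference, and it shows that methylsulfanyl there stands clearly apart from the unsubstituted compound in this assay: the change is a 16-fold higher number from compound 1 to compound 4 (1.21 log units; beyond the scatter). Methoxy, by contrast, cannot yet be separated from hydrogen, since the step is an at least 1.6-fold lower number from compound 3 to compound 4 (0.20 log units; that floor lies within the scatter), and the exchange of the selenium atom for methylsulfanyl on the shared core is no clearer, with an at least 1.6-fold lower number from compound 2 to compound 4 (0.20 log units; that floor lies within the scatter). Both steps start from a limit and so give only a floor, which means neither a real change nor its absence can be claimed from them: the limit of > 100000 nM in this assay, at which 2 of the 4 values shown sit.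

The compounds shown leave open whether the lower number belongs to methylsulfanyl alone or would also appear with another group on this aromatic carbon, such as an amine, a chlorine atom or a longer sulfur-bearing chain. They also leave open whether the gap between methylsulfanyl and hydrogen at this place would persist if the other methylsulfanyl group of the shared core were replaced by a different group, such as an amine.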